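Ring swaps on the sulfonamide nitrogen side chain: lipophilicity notes

The source may hold more compounds than are shown below. What is called first, only, known or untested is meant among the compounds shown, and "the series" means these compounds.

Compound 1 `CC1(C)C[C@H](CN([C@H](CCC(F)(F)F)C(N)=O)S(=O)(=O)c2ccc(Cl)cc2)O1` gives 3.8 in a physicochemical assay for lipophilicity, read by HPLC, measured as octanol-water partition, at pH 7.4 (on this read-out higher numbers stand for higher lipophilicity and lower numbers for lower lipophilicity), the second highest of the three numbers measured. Compound 2 `NC(=O)[C@@H](CCC(F)(F)F)N(C[C@@H]1CCCCO1)S(=O)(=O)c1ccc(Cl)cc1` gives 4.3 and compound 3 `NC(=O)[C@@H](CCC(F)(F)F)N(C[C@H]1CCCOC1)S(=O)(=O)c1ccc(Cl)cc1` gives 3.6; the step of a number 0.50 log units higher from compound 1 to compound 2 (beyond the scatter) lies beyond the scatter, whereas a number 0.20 log units lower from compound 1 to compound 3 (within the scatter) does not, and a number 0.70 log units lower from compound 2 to compound 3 (beyond the scatter) is the largest step of the set. Compound 4 `NC(=O)[C@@H](CCC(F)(F)F)N(C[C@@H]1CCO1)S(=O)(=O)c1ccc(Cl)cc1` differs from compound 1 by oxetan-2-yl in place of 4,4-dimethyloxetan-2-yl on a saturated chain carbon bound to a sulfonamide nitrogen. For the measured compounds named here, no measured step removes two carbons from the ring while keeping the ring size; the nearest, from compound 1 to compound 2, exchanges one six-heavy-atom group for another. With the group shrinking from six heavy atoms to four, a lowering in this assay is expected for compound 4, a number 0.90 log units lower from compound 1 to compound 4 (beyond the scatter). Compound 4 is estimated at 2.9, with a range from 2.5 to 3.3.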

Compound 4, distribution coefficient: 2.6
Beside the measured number, compound 4's estimate is 0.30 log units above it; low and high end bracket the measured number.
By their numbers in this assay, from the lowest: compound 4; then compounds 3 and 1 (each within the scatter of the next); then compound 2.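

In this assay oxetan-2-yl in place of 4,4-dimethyloxetan-2-yl keeps the four-membered ring yet gives a number 1.20 log units lower from compound 1 to compound 4 (beyond the scatter) and so shows a large change at this position with ring size held. The oxan-3-yl and oxan-2-yl groups also read higher than oxetan-2-yl, with a number 1.00 log units lower from compound 3 to compound 4 (beyond the scatter) and a number 1.70 log units lower from compound 2 to compound 4 (beyond the scatter) widening the range seen at this position.

On these data alone, how an amine or a carboxylic acid on the saturated chain carbon bound to the sulfonamide nitrogen would read in this assay stays open. No evidence shown explains the size of these steps.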